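Adding a methoxy to compound 2

This account rests on a few compounds, and the source may have more. Where it says the series, first, only, none or still open, it means among the compounds named here.

Of the compounds shown here, three sharing one core have been tested in a functional assay on MCF7 cells (Homo sapiens) for antiproliferative activity, read by WST assay, with a stated time of 72 h; a higher number here means a weaker inhibitor, a lower number a stronger inhibitor. Compound 1 `COc1ccc2[nH]c(-c3nc(-c4ccccc4)no3)cc2c1` carries a methoxy and reports only a limit of the assay, > 50000 nM. Compound 2 `Fc1ccc2[nH]c(-c3nc(-c4ccccc4)no3)cc2c1` carries a fluoro instead and gives 35000 nM; compound 3 `Clc1ccc2[nH]c(-c3nc(-c4ccccc4)no3)cc2c1` carries a chloro and gives 29100 nM. Compound 2 therefore stands alongside compound 3, separated by a 1.2-fold lower number from compound 2 to compound 3 (0.08 log units; within the scatter), while compound 1 contributes only a limit (the limit of > 50000 nM in this assay, at which 1 of the 3 values shown sits). The unmeasured compound 4 `COc1ccc(-c2noc(-c3cc4cc(F)ccc4[nH]3)n2)cc1` differs from compound 2 by methoxy in place of hydrogen on an aromatic carbon. The measured steps of an at least 1.4-fold lower number from compound 1 to compound 2 (0.15 log units; that floor lies within the scatter) and an at least 1.7-fold lower number from compound 1 to compound 3 (0.23 log units; that floor lies within the scatter) describe swapping a methoxy for a halogen, not adding one, so they bear only loosely. No step beyond the scatter is expected: the step from compound 2 to compound 4 is estimated at a 1.2-fold lower number from compound 2 to compound 4 (0.07 log units; within the scatter). Compound 4 is thus expected at 30000 nM, between 10000 nM and 90000 nM.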

Compound 4, half-maximal inhibitory concentration: > 50000 nM
Compound 4 ended at the assay's limit (the forecaster's own chance of this, stated with the estimate: 35%); at least 1.6-fold (0.22 log units) between middle value and limit.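

In this assay compound 4 gives > 50000 nM, which is a limit of the assay and not a number. For the compounds shown here, the earlier compounds varied a different place, so this is the first reading for methoxy in place of hydrogen para to a large group: an at least 1.4-fold higher number from compound 2 to compound 4 (0.15 log units; that floor lies within the scatter), which shows no gain in strength, though the true size of the step stays unknown. The limit now holds more of the set: the limit of > 50000 nM in this assay, at which 2 of the 4 values shown sit.

As far as these compounds go, how far past the limit compound 4 really lies stays open. So does whether an amine or a carboxylic acid at this same position would lower the number.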